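The source may report more compounds than this note shows. Statements on the series, on what has been measured and on what is new or still open speak of the compounds shown alone.

Measured so far:
compound 1, `CCCCc1ccc(CNC(=O)OC(C)(C)C)c(=O)n1Cc1ccc(-c2ccccc2-c2nn[nH]n2)cc1`: 68.9%
compound 2, `CCCCc1ccc(CNC(=O)N(C)C)c(=O)n1Cc1ccc(-c2ccccc2-c2nn[nH]n2)cc1`: 28%

For the measured compounds named here, in a functional assay on the whole organism (artery) for inhibition, with Rattus norvegicus as the target, at a dose of 3 mg/kg by the intraduodenal route (on this read-out higher numbers stand for more inhibition at the one dose given (going by the name of the read-out) and lower numbers for less inhibition), compound 1 stands highest of the two numbers known, and its only neighbour is compound 2, reached by a number 40.9 percentage points lower from compound 1 to compound 2 (beyond the scatter), a change of dimethylamino in place of tert-butoxy on a carbonyl carbon. Compound 3, `CCCCc1ccc(CNS(C)(=O)=O)c(=O)n1Cc1ccc(-c2ccccc2-c2nn[nH]n2)cc1`, has not been measured; it differs from compound 1 by methylsulfonyl in place of tert-butoxycarbonyl on an amine nitrogen. Going by the values given here, no measured step has this same change, so only the step from compound 1 to compound 2 bears on it, and that one indirectly: it shows that replacing the tert-butoxy part of the tert-butoxycarbonyl group with another group lowered the read-out by a large amount. A drop beyond the scatter is therefore expected here as well, though its size is uncertain. Compound 3 is estimated at 40%, within 15% to 65%, which means an expected step of a number 28.9 percentage points lower from compound 1 to compound 3 (beyond the scatter).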

Compound 3, a percentage reported as inhibition, in the whole organism at one dose (the size of the read-out at that dose, not a potency): 54.8%
Beside the measured number, compound 3's estimate is 14.8 percentage points below it; the range from low to high includes it.
By their numbers in this assay, from the lowest: compound 2; then compound 3; then compound 1.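

In this assay the result shows that the group on this amine nitrogen need not be a carbonyl group to keep a sizeable read-out: methylsulfonyl, with 4 heavy atoms against the 7 of tert-butoxycarbonyl, gives a number 14.1 percentage points lower from compound 1 to compound 3 (beyond the scatter) and so costs far less than the dimethylamino change did. The step of a number 26.8 percentage points higher from compound 2 to compound 3 (beyond the scatter) adds that methylsulfonyl reads clearly above dimethylcarbamoyl, so the carbonyl-bearing groups do not sit together in the order, and compound 1 and compound 2 lie on either side of compound 3. No measurement is available that would explain this order.

The compounds shown leave open how an acetyl group or a free amine would read on this nitrogen. They also leave open whether a longer chain on the sulfonyl, such as ethylsulfonyl, would move the read-out up or down.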